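The source may report more compounds than this note shows. Statements on the series, on what has been measured and on what is new or still open speak of the compounds shown alone.

Measured so far:
compound 1, `CNC(=O)c1cc(Oc2ccc(NC(=O)c3nn(-c4ccccc4OC(F)(F)F)c(=O)cc3C)cc2F)ccn1`, > 40000 nM
compound 2, `CNC(=O)c1cc(Oc2ccc(NC(=O)c3nn(-c4cccc(F)c4)c(=O)cc3C)cc2F)ccn1`, 9540 nM
compound 3, `Cc1cc(=O)n(-c2ccccc2OC(F)(F)F)nc1C(=O)Nc1ccc(Oc2ncnc3ccsc23)cc1`, 10100 nM

All three were tested in a functional assay on A549 cells (Homo sapiens) for cytotoxicity, read by MTT assay, with a stated time of 72 h; a higher number here means a weaker inhibitor, a lower number a stronger inhibitor. Compound 1 gives only a limit there, > 40000 nM, so its true value is not known. Compound 2 gives 9540 nM, and compound 3 gives 10100 nM; these two numbers lie within the usual scatter of each other, so no order can be read between them. Compound 2 arises from compound 1 by a single change, (3-fluorophenyl in place of 2-(trifluoromethoxy)phenyl on an aromatic nitrogen), and the step is an at least 4.1-fold lower number from compound 1 to compound 2 (0.62 log units; beyond the scatter). This step can be stated only as a lower bound because of the limit of > 40000 nM in this assay, at which 1 of the 3 values shown sits. Compound 3 is built on a different core from compound 1; the difference between the two cores is not broken down here.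

Compound 4, `Cc1cc(=O)n(-c2cccc(F)c2)nc1C(=O)Nc1ccc(Oc2ncnc3ccsc23)cc1`, has not yet been measured in this assay. It comes from compound 3 by the same change, (3-fluorophenyl in place of 2-(trifluoromethoxy)phenyl on an aromatic nitrogen), and the surroundings of the change are the same in both pairs, so it is the same change. Since that change gave the step of an at least 4.1-fold lower number from compound 1 to compound 2 (0.62 log units; beyond the scatter), a step in the same direction is expected here, a 4.0-fold lower number from compound 3 to compound 4 (0.61 log units; beyond the scatter), though the earlier step rests on a limit and the real effect may be larger than it shows. Compound 4 is therefore estimated at 2500 nM, with an expected range from 700 nM to 9000 nM.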

Compound 4, half-maximal inhibitory concentration: 9540 nM
Compound 4: the middle estimate sits 3.8-fold (0.58 log units) below what was measured; the measured number lies above the stated range.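

In this assay, putting 3-fluorophenyl in place of 2-(trifluoromethoxy)phenyl on the aromatic nitrogen gives a 1.1-fold lower number from compound 3 to compound 4 (0.02 log units; within the scatter), so on this core the swap makes no readable difference. The effect seen on the core of compound 1 therefore did not carry over to the core of compound 3, and the two steps stand clearly apart: the same change on two cores in this assay, an at least 4.1-fold lower number (0.62 log units; beyond the scatter) from compound 1 to compound 2 and a 1.1-fold lower number (0.02 log units; within the scatter) from compound 3 to compound 4, at least 3.9-fold (0.59 log units) apart, beyond the scatter of two such steps. From the compounds shown here alone, this does not show why the two cores respond differently, nor how large the first step really is, since compound 1 gives only a limit and its true value is unknown: the limit of > 40000 nM in this assay, at which 1 of the 4 values shown sits.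

The swap removes one group and brings in another at once, so the compounds shown leave open how much of the step on the first core comes from losing 2-(trifluoromethoxy)phenyl and how much from gaining 3-fluorophenyl. An unsubstituted phenyl on the same aromatic nitrogen would help separate the two, and a phenyl ring carrying an amine or a carboxylic acid would show whether the two cores also part ways with other groups.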